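Series notes: pyrrolidin-1-yl in place of cyclohexyloxy

The source may hold more compounds than are shown below. What is called first, only, known or untested is meant among the compounds shown, and "the series" means these compounds.

The series keeps one acylguanidine core and varies a single substituent on the aromatic ring. Compound 1 `Cc1cc(F)c(S(C)(=O)=O)cc1C(=O)N=C(N)N` carries fluoro there; in a functional assay for inhibition of sodium/hydrogen exchanger (Oryctolagus cuniculus) (on this read-out lower numbers stand for stronger inhibition and higher numbers for weaker inhibition), compound 1 gives 44 nM. Compound 2 `CCOc1cc(C)c(C(=O)N=C(N)N)cc1S(C)(=O)=O` carries ethoxy and in this assay compound 2 gives 19 nM. Compound 3 `Cc1cc(OC2CCCCC2)c(S(C)(=O)=O)cc1C(=O)N=C(N)N` carries cyclohexyloxy and in this assay compound 3 gives 37 nM. Among the three numbers compound 3 stands second highest: the step of a 1.2-fold lower number from compound 1 to compound 3 (0.08 log units; within the scatter) lies within the scatter, as does a 1.9-fold higher number from compound 2 to compound 3 (0.29 log units; within the scatter); only a 2.3-fold lower number from compound 1 to compound 2 (0.36 log units; beyond the scatter) goes beyond it.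

Compound 4 `Cc1cc(N2CCCC2)c(S(C)(=O)=O)cc1C(=O)N=C(N)N` is the untested member. Its change from compound 3 is pyrrolidin-1-yl in place of cyclohexyloxy on an aromatic carbon. Among the measured compounds shown here, the steps that bear on this change are those at the same aromatic carbon: a 1.9-fold higher number from compound 2 to compound 3 (0.29 log units; within the scatter) and a 1.2-fold lower number from compound 1 to compound 3 (0.08 log units; within the scatter), both within the scatter, and a 2.3-fold lower number from compound 1 to compound 2 (0.36 log units; beyond the scatter), which is modest. Three groups of quite different shape at this carbon gave numbers spanning little more than the scatter, so a further exchange there is expected to give no step beyond it, with no direction favoured.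

Compound 4 is therefore estimated at 30 nM in this assay, within 10 nM to 90 nM. The expected step of a 1.2-fold lower number from compound 3 to compound 4 (0.09 log units; within the scatter) is small.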

Compound 4, half-maximal inhibitory concentration: 11 nM
Beside the measured number, compound 4's estimate is 2.7-fold (0.44 log units) above it; low and high end bracket the measured number.
By their numbers in this assay, from the lowest: compounds 4, 2, 3 and 1 (each within the scatter of the next, the first and the last beyond it).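

Among the compounds shown here, at this aromatic carbon, ortho to a methylsulfonyl group, the earlier exchanges of fluoro, ethoxy and cyclohexyloxy left only one step beyond the scatter, but in this assay pyrrolidin-1-yl adds two more: one against cyclohexyloxy (a 3.4-fold lower number from compound 3 to compound 4 (0.53 log units; beyond the scatter)) and one against fluoro (a 4.0-fold lower number from compound 1 to compound 4 (0.60 log units; beyond the scatter)). The position therefore responds to the group placed on it more than the first three compounds suggested, although the step against ethoxy (a 1.7-fold lower number from compound 2 to compound 4 (0.24 log units; within the scatter)) stays within the scatter, so compound 2 and compound 4 cannot be told apart, and only compound 4 stands clear of both compound 1 and compound 3. Nothing among the data shown accounts for these steps.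

Compound 4 differs from compound 3 both in the atom attached to the aromatic carbon, nitrogen in place of oxygen, and in the ring, five-membered in place of six-membered, and the compounds shown do not separate these two changes. Cyclopentyloxy, piperidin-1-yl or an open-chain dimethylamino group at this carbon would take them apart.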